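Aryl substituent changes in one series: estimate for compound 4

The compounds below may be only part of what the source reports. "The series", "measured", "known", "first", "only" and "open" are said of these compounds alone.

Measured so far in a functional assay on the whole organism (strain Swiss albino) with Mus musculus as the target, with a stated time of 4 h; a higher number here means that more compound is needed for the effect, a lower number that less compound is needed:
compound 1 `C=C(C)[C@@H]1CC=C(C)/C(=N/NC(=O)Nc2nnc(-c3ccc(OC)cc3)o2)C1` gives 300 mg/kg
compound 2 `C=C(C)[C@@H]1CC=C(C)/C(=N/NC(=O)Nc2nnc(-c3ccc([N+](=O)[O-])cc3)o2)C1` gives 300 mg/kg
compound 3 `C=C(C)[C@@H]1CC=C(C)/C(=N/NC(=O)Nc2nnc(-c3ccccc3O)o2)C1` gives 300 mg/kg

Compound 1 stands level with compounds 2 and 3 on these numbers. Each of the three measured compounds shares the same core and differs only in the aryl ring attached to it. The step of no change at the digits printed from compound 1 to compound 2 (within the scatter) and the step of no change at the digits printed from compound 1 to compound 3 (within the scatter) are both within the scatter, as is the step of no change at the digits printed from compound 2 to compound 3 (within the scatter). Nothing in the measured set therefore separates a methoxy, a nitro or a hydroxy substituent on that ring.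

Compound 4 `C=C(C)[C@@H]1CC=C(C)/C(=N/NC(=O)Nc2nnc(-c3ccc(O)cc3)o2)C1` is not yet measured. It differs from compound 1 by hydrogen in place of methyl on an oxygen on an aromatic ring. The change again sits on the aryl ring, the same region varied by the three measured steps, all of which stayed within the scatter. On that basis no step beyond the scatter is expected from compound 1 to compound 4 in this assay.

Compound 4 is therefore estimated at 300 mg/kg, in the range 150 mg/kg to 600 mg/kg, which means an expected step of no change at the digits printed from compound 1 to compound 4 (within the scatter).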

Compound 4, minimum effective dose: 300 mg/kg
Compound 4: middle estimate and measured number agree at the digits printed; the range from low to high includes it.
By their numbers in this assay, from the lowest: compounds 1, 2, 3 and 4 (each within the scatter of the next).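

In this assay, among these compounds, hydrogen in place of methyl on the oxygen gives no change at the digits printed from compound 1 to compound 4 (within the scatter) and so provides the first direct comparison of a free hydroxy with a methoxy at one place on the aryl ring, with the two not separated. The 4-hydroxyphenyl and 2-hydroxyphenyl groups are also not separated, with no change at the digits printed from compound 3 to compound 4 (within the scatter) as the step, and this isolates the place of the hydroxy in a way the earlier comparison of the 2-hydroxyphenyl and 4-methoxyphenyl groups could not, while hydroxy in place of nitro at a single place gives no change at the digits printed from compound 2 to compound 4 (within the scatter) and likewise shows no separation. No measured evidence bears on why these aryl changes read alike.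

From the compounds shown here alone, all four compounds stand level, so it remains open whether any aryl substituent can shift the minimum effective dose, for instance an amine, a carboxylic acid or a longer chain such as butoxy in place of methoxy. The compounds shown also leave open how far this insensitivity holds for changes away from the aryl ring, since all of them keep the shared core.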